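Swapping the aryl group on the piperazine nitrogen

A few compounds are considered here, and "the series" means these few. Any claim that something is new, unique, unknown or untested is made for them only; others in the source may bear on it.

Compound 1 `CCN(Cc1ccncc1)C(=S)SCc1ccc(C(=O)Nc2ccccc2N)cc1` gives 85.2% in a functional assay on MGC-803 cells (Homo sapiens) for antiproliferative activity, read by CCK-8 assay, with a stated time of 72 h, tested at 8 uM (on this read-out higher numbers stand for a stronger effect at the one concentration tested and lower numbers for a weaker effect), compound 2 `Nc1ccccc1NC(=O)c1ccc(CSC(=S)N2CCN(Cc3ccccc3)CC2)cc1` gives 19.7%, and compound 3 `Nc1ccccc1NC(=O)c1ccc(CSC(=S)N2CCN(c3ccccc3F)CC2)cc1` gives 86.4%. The number for compound 3 is the highest of the three, but compound 1 sits within the scatter of it, while compound 2 lies far below. Among the compounds with values here, the one measured step, a number 66.7 percentage points higher from compound 2 to compound 3 (beyond the scatter), is large and concerns a 2-fluorophenyl replacing a benzyl. Compound 4 `Cc1ccc(N2CCN(C(=S)SCc3ccc(C(=O)Nc4ccccc4N)cc3)CC2)cc1` differs from compound 3 by 4-methylphenyl in place of 2-fluorophenyl on an amine nitrogen in a ring. Within the data shown here, no measured step compares two aryl groups of this kind directly, so no shift beyond the scatter is expected; the step from compound 3 to compound 4 is estimated at a number 6.4 percentage points lower from compound 3 to compound 4 (within the scatter). Compound 4 is expected to give 80%, between 55% and 92%.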

Compound 4, a percentage reported as inhibition, at one concentration (the size of the read-out at that concentration, not a potency): 19.8%
Compound 4: middle estimate off by 60.2 percentage points, on the high side; the whole stated range lies above it.
By their numbers in this assay, from the lowest: compounds 2 and 4 (each within the scatter of the next); then compounds 1 and 3 (each within the scatter of the next).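

Replacing 2-fluorophenyl with 4-methylphenyl gives a number 66.6 percentage points lower from compound 3 to compound 4 (beyond the scatter), so a phenyl ring carried directly on this ring nitrogen does not by itself secure a high number. Replacing benzyl with 4-methylphenyl gives a number 0.1 percentage points higher from compound 2 to compound 4 (within the scatter), so a low number is not confined to the benzyl group. No measurement available here explains the gap between the two aryl groups. The change alters both the atom or group on the phenyl ring and where it sits, and the compounds shown do not separate these two changes. On these data alone, how an unsubstituted phenyl or a chlorophenyl would compare also remains open.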